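The source may report more compounds than this note shows. Statements on the series, on what has been measured and on what is new or still open speak of the compounds shown alone.

Measured compounds:
compound 1 `Cc1ccc(-c2cn(C[C@H](O)[C@H]3OC(=O)C(OCc4ccccc4)=C3OCc3ccccc3)nn2)cc1` — in a functional assay on HeLa cells (Homo sapiens) for antiproliferative activity, read by MTT assay, with a stated time of 72 h (a higher number here means a weaker inhibitor, a lower number a stronger inhibitor), compound 1 gives 25500 nM
compound 2 `C[Si](C)(C)c1cn(C[C@H](O)[C@H]2OC(=O)C(OCc3ccccc3)=C2OCc2ccccc2)nn1` — in this assay compound 2 gives 22300 nM

Compound 2 stands at the lower of the two numbers, though the measured step between them, a 1.1-fold lower number from compound 1 to compound 2 (0.06 log units; within the scatter), lies within the scatter. Compound 3 `Cc1ccc(S(=O)(=O)NCc2cn(C[C@H](O)[C@H]3OC(=O)C(OCc4ccccc4)=C3OCc3ccccc3)nn2)cc1` differs from compound 2 by a group of 12 heavy atoms (8 carbon, 1 nitrogen, 2 oxygen, 1 sulfur; one six-membered aromatic ring of carbon only) in place of a group of 4 heavy atoms (3 carbon, 1 silicon; no ring), on an aromatic carbon. The only measured step, from compound 1 to compound 2, swapped groups at this same aromatic carbon without moving the number beyond the scatter, so the group on this carbon has so far shown no influence in this assay. For the measured compounds named here, the new group is larger and carries a hydrogen-bond donor, for which no step is on record. Compound 3 is therefore expected near compound 2, a step of a 1.1-fold lower number from compound 2 to compound 3 (0.05 log units; within the scatter), with an estimate of 20000 nM and a range from 7000 nM to 60000 nM.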

Compound 3, half-maximal inhibitory concentration: 14400 nM
Compound 3: the middle estimate sits 1.4-fold (0.14 log units) above what was measured, and the stated range covers the measured number.
By their numbers in this assay, from the lowest: compounds 3, 2 and 1 (each within the scatter of the next).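

In this assay, both new steps, a 1.5-fold lower number from compound 2 to compound 3 (0.19 log units; within the scatter) and a 1.8-fold lower number from compound 1 to compound 3 (0.25 log units; within the scatter), stay within the scatter. For the compounds shown here, the aromatic carbon has now carried (((4-methylphenyl)sulfonyl)amino)methyl, the first group here with a hydrogen-bond donor and acceptors, and three quite different groups at this place have yet to give a step beyond the scatter. Nothing on hand bears on why the number stays where it does. From the compounds shown here alone, whether an amine or a carboxylic acid on this carbon would give such a step remains open, as does whether a change elsewhere on the shared core would.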